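Shared core series: nitro in place of trifluoromethyl

This account rests on a few compounds, and the source may have more. Where it says the series, first, only, none or still open, it means among the compounds named here.

Compound 1 `COc1cc(/C=C/c2ccc(OC(=O)/C=C/c3ccccc3)cc2)cc(OC)c1` gives 9050 nM in a functional assay on HT-29 cells (Homo sapiens) for inhibition, read by MTT assay, with a stated time of 48 h; on this read-out higher numbers stand for weaker inhibition and lower numbers for stronger inhibition. Compound 2 `COc1cc(/C=C/c2ccc(OC(=O)/C=C/c3ccc(C(F)(F)F)cc3)cc2)cc(OC)c1` carries trifluoromethyl where compound 1 carries hydrogen. In this assay compound 2 gives 9090 nM. The step of a 1.0-fold higher number from compound 1 to compound 2 (0.00 log units; within the scatter). On the two numbers shown, compound 2 and compound 1 therefore lie within the scatter of each other, and no value stands apart from them.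

Compound 3 `COc1cc(/C=C/c2ccc(OC(=O)/C=C/c3ccc([N+](=O)[O-])cc3)cc2)cc(OC)c1` has not yet been measured. It differs from compound 2 by nitro in place of trifluoromethyl on an aromatic carbon, on an aromatic carbon of a six-membered aromatic ring of carbon only, para to a large group. Among the measured compounds shown here, the only measured step, from compound 1 to compound 2, concerns the same carbon but a different exchange, and it produced no shift beyond the scatter. For the measured compounds named here, no measured step involves a nitro group, so there is no direct precedent for this change. The expectation for compound 3 is that a 1.0-fold lower number from compound 2 to compound 3 (0.00 log units; within the scatter), with no step beyond the scatter. Compound 3 is estimated at 9000 nM, within a range from 4000 nM to 20000 nM.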

Compound 3, half-maximal inhibitory concentration: > 20000 nM
Compound 3: a limit, no number; the forecaster's own chance of this, stated with the estimate: 5%; middle value at least 2.2-fold (0.34 log units) from the limit.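

The aromatic carbon para to a large group is not indifferent to what it carries: the hydrogen and trifluoromethyl compounds gave no separable values, but nitro does separate from both. In this assay, nitro in place of trifluoromethyl gives an at least 2.2-fold higher number from compound 2 to compound 3 (0.34 log units; beyond the scatter), and nitro in place of hydrogen gives an at least 2.2-fold higher number from compound 1 to compound 3 (0.34 log units; beyond the scatter), so inhibition is weaker with nitro than with either earlier group. The value of compound 3 is a limit of the assay and not a number, and each step to it gives a minimum size only: the limit of > 20000 nM in this assay, at which 1 of the 3 values shown sits.

On these data alone, whether weaker inhibition is particular to nitro or also appears with other groups on this carbon, such as an amine or a carboxylic acid, remains open. The compounds shown give no measured property that could account for the step, and they do not tell whether nitro would have the same effect on another carbon of the same ring.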